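Butylamino to isobutylamino on the methoxy compounds

The source may hold more compounds than are shown below. What is called first, only, known or untested is meant among the compounds shown, and "the series" means these compounds.

Values in an ADME assay on HepG2 cells (Homo sapiens) for cytotoxicity, read by CellTiter-Glo, with a stated time of 48 h; a higher number here means that more compound is tolerated, a lower number that less compound is tolerated:
- compound 1 `COc1ccc2nc(NCCO)c(S(C)(=O)=O)nc2c1` gives 39800 nM
- compound 2 `CCCCNc1nc2ccccc2nc1S(C)(=O)=O` gives 12600 nM
- compound 3 `CCCCNc1nc2cc(OC)ccc2nc1S(C)(=O)=O` gives > 100000 nM

Compound 3 stands at > 100000 nM as a limit of the assay, not a number. Compound 4 `COc1ccc2nc(S(C)(=O)=O)c(NCC(C)C)nc2c1` has the same atoms as compound 3, joined differently: isopropyl in place of propyl on a saturated chain carbon bound to a nitrogen on an aromatic ring, which reads as butyl to isobutyl, with isopropyl in place of propyl on a saturated chain carbon bound to a nitrogen on an aromatic ring.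

Among the measured compounds shown here, the one measured step is an at least 7.9-fold higher number from compound 2 to compound 3 (0.89 log units; beyond the scatter), and it concerns methoxy in place of hydrogen, not the chain. For the measured compounds named here, no measured step alters the chain in this way, so that step gives no size for this change. Compound 1 also carries methoxy and gives 39800 nM as a measured number. No step beyond the scatter is expected in this assay. The expected step is an at least 1.2-fold lower number from compound 3 to compound 4 (0.09 log units; that floor lies within the scatter), with a limit reading again quite possible. For compound 4 the estimate is 80000 nM, with an expected range of 30000 nM to 120000 nM.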

Compound 4, half-maximal cytotoxic concentration: 79400 nM
Beside the measured number, compound 4's estimate is 1.0-fold (0.00 log units) above it; the measured number falls inside the stated range.
By their numbers in this assay, from the lowest: compound 2; then compounds 1 and 4 (each within the scatter of the next). At a limit, above all of these: compound 3.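

In this assay, butylamino to isobutylamino on the methoxy compounds gives an at least 1.2-fold lower number from compound 3 to compound 4 (0.10 log units; that floor lies within the scatter), the only step shown that alters the chain, and it stays within the scatter at its floor. Compound 4 gives 79400 nM, so this isobutylamino chain on the methoxy core yields a measured number rather than a limit. Compound 3 gives > 100000 nM, which is a limit of the assay and not a number, so the step remains a floor and its true size cannot be read: the limit of > 100000 nM in this assay, at which 1 of the 4 values shown sits.

Still open, from the compounds shown here alone, is how a longer chain, a cyclopropylmethyl group or a terminal amine or carboxylic acid on the chain would read on the methoxy core. Also open, going by these compounds, is whether butyl to isobutyl gives a step of measurable size on the core without methoxy.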